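The source may report more compounds than this note shows. Statements on the series, on what has been measured and on what is new or still open speak of the compounds shown alone.

Working notes on the series, read in a functional assay on HCT-116 cells (Homo sapiens) for inhibition, read by MTT assay, with a stated time of 2 days, tested at 10 uM; a lower number here means less inhibition, a higher number more inhibition at the concentration tested (going by the name of the read-out).

Compound 1 `COc1ccc(OC)c(-c2cn(-c3ccc(O)c(C(=O)Nc4cccc(C(F)(F)F)c4)c3)nn2)c1` gives 46% in this assay. Compound 2 `COc1ccc(-c2cn(-c3ccc(O)c(C(=O)Nc4cccc(C(F)(F)F)c4)c3)nn2)cc1` gives 9% in this assay. Compound 3 `COc1ccc(-c2cn(-c3ccc(O)c(C(=O)OCCCc4ccccc4)c3)nn2)cc1` gives 12% in this assay.

Compound 3 differs from compound 2 in one place: 3-phenylpropoxy in place of (3-(trifluoromethyl)phenyl)amino on a carbonyl carbon. That change gave a number 3 percentage points higher from compound 2 to compound 3 (within the scatter), so the two cores, the amide and the ester, stand level with each other within the usual scatter. Compound 1 differs from compound 2 in one place: 2,5-dimethoxyphenyl in place of 4-methoxyphenyl on an aromatic carbon. Within the data shown here, that change gave a number 37 percentage points higher from compound 2 to compound 1 (beyond the scatter), the only step beyond the scatter among the three measured compounds.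

Compound 4 `COc1ccc(OC)c(-c2cn(-c3ccc(O)c(C(=O)OCCCc4ccccc4)c3)nn2)c1` has not yet been measured in this assay. It differs from compound 3 in one place: 2,5-dimethoxyphenyl in place of 4-methoxyphenyl on an aromatic carbon. Among the measured compounds shown here, this is the same change as the one from compound 2 to compound 1, with the same surroundings at the place, and it occurs twice among the compounds here. The two cores on which it sits differ by the carbonyl substituent described above.

Because a number 37 percentage points higher from compound 2 to compound 1 (beyond the scatter) was large, and because a number 3 percentage points higher from compound 2 to compound 3 (within the scatter) shows the two cores behaving alike, the same change on the ester core is expected to act in the same way. The estimated step is therefore a number 33 percentage points higher from compound 3 to compound 4 (beyond the scatter). For the measured compounds named here, only one precedent exists, so the range is kept wide. Compound 4 is therefore expected to give about 45% in this assay, most likely between 22% and 68%.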

Compound 4, a percentage reported as inhibition, at one concentration (the size of the read-out at that concentration, not a potency): 13%
Estimate against measurement, compound 4: 32 percentage points above; the whole stated range lies above it.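

In this assay, 2,5-dimethoxyphenyl in place of 4-methoxyphenyl gave a number 1 percentage points higher from compound 3 to compound 4 (within the scatter), so the large gain seen on the core of compound 1 did not carry over to the ester core: the same change on two cores in this assay, a number 37 percentage points higher (beyond the scatter) from compound 2 to compound 1 and a number 1 percentage points higher (within the scatter) from compound 3 to compound 4, 36 percentage points apart, beyond the scatter of two such steps. The carbonyl change, which made no difference beyond the scatter while 4-methoxyphenyl was present, gave a number 33 percentage points lower from compound 1 to compound 4 (beyond the scatter) with 2,5-dimethoxyphenyl present, so the two changes cannot be treated as separate contributions in this series: the same change on two cores in this assay, a number 3 percentage points higher (within the scatter) from compound 2 to compound 3 and a number 33 percentage points lower (beyond the scatter) from compound 1 to compound 4, 36 percentage points apart, beyond the scatter of two such steps. This shows that the effect of the change depends on the core in these four compounds, but with one pair on each core it does not show which part of the carbonyl substituent decides the outcome, or whether other aryl groups would behave the same way.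

The amide and ester differ at the link and also in the group beyond it, so a 3-phenylpropylamino group or a 3-(trifluoromethyl)phenoxy group on the carbonyl carbon would be needed to separate the two. Also open, as far as these compounds go, is whether both methoxy groups of 2,5-dimethoxyphenyl are needed for the value of compound 1, and whether an ethoxy or a chloro group in their place would do the same.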